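Fluoro on the benzoyl ring of the sulfonamide series

A few compounds are considered here, and "the series" means these few. Any claim that something is new, unique, unknown or untested is made for them only; others in the source may bear on it.

Within the data shown here, compound 2 `O=C(NCc1ccc(CNS(=O)(=O)c2ccccc2)cc1)c1ccccc1` is the one member with a number rather than a limit in an assay on MDA-MB-231 cells for binding affinity to C-X-C chemokine receptor type 4 (Homo sapiens), read by immunofluorescence and microscopy, with stated times of 10 min and 30 min (on this read-out higher numbers stand for an effect only at larger amounts of compound and lower numbers for an effect already at smaller amounts), where compound 2 gives 1 nM. Compound 1 `Cc1ccc(S(=O)(=O)NCc2ccc(CNC(=O)c3ccccc3)cc2)cc1` gives only a limit of the assay, > 1000 nM. Compound 3 `Cc1ccc(S(=O)(=O)NCc2ccc(CNC(=O)c3cccnc3)cc2)cc1` likewise gives only a limit, > 1000 nM. Two of the three values thus sit at the limit of > 1000 nM in this assay, at which 2 of the 3 values shown sit. The step of an at least 1000-fold lower number from compound 1 to compound 2 (3.00 log units; beyond the scatter) is hydrogen in place of methyl on an aromatic carbon; the step that the two limits leave unreadable from compound 1 to compound 3 is pyridin-3-yl in place of phenyl on a carbonyl carbon. Compound 4 `O=C(NCc1ccc(CNS(=O)(=O)c2ccccc2)cc1)c1cccc(F)c1` differs from compound 2 by fluoro in place of hydrogen on an aromatic carbon, reading benzoyl to (3-fluorophenyl)carbonyl. Neither measured step concerns this change, so no step beyond the scatter is expected, a 2.0-fold higher number from compound 2 to compound 4 (0.30 log units; within the scatter). For compound 4 the expected value in this assay is 2 nM, between 0.3 nM and 30 nM.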

Compound 4, effective concentration (reported as EC, without a stated level of effect): 100 nM
The estimate for compound 4 lay 50-fold (1.70 log units) below the measured number, outside the stated range (above it).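

In this assay, the benzoyl ring of compound 2 proves sensitive to a single added atom: fluoro in place of hydrogen, on an aromatic carbon meta to a large group, gives a 100-fold higher number from compound 2 to compound 4 (2.00 log units; beyond the scatter). Among these compounds, this is the first readable step on this ring, since the earlier change there, pyridin-3-yl in place of phenyl, could not be read between two limits. Nothing shown bears on the reason for this step.

Going by these compounds, whether chloro, methoxy or an amine at the same carbon would give a similar rise stays open. So does the effect of fluoro on the other carbons of this ring.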